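Carbamate in place of allyl on the ring nitrogen

The source may hold more compounds than are shown below. What is called first, only, known or untested is meant among the compounds shown, and "the series" means these compounds.

The series is read in a functional assay on ileum for antagonist activity at muscarinic acetylcholine receptor M3 (Cavia porcellus); on this read-out lower numbers stand for stronger inhibition and higher numbers for weaker inhibition. Compound 1 `C=CCN1CCN(CC(=O)C(O)(c2ccccc2)C2CCCCC2)CC1` gives 25.6 nM and stands highest of the two plain numbers shown. Compound 2 `O=C(CN1CCN(C/C=C\c2ccccc2)CC1)C(O)(c1ccccc1)C1CCC1` gives 9.92 nM, a lower number that sits beyond the scatter. Compound 3 `O=C(CN1CCN(c2ccc([N+](=O)[O-])cc2)CC1)C(O)(c1ccccc1)C1CCC1` returns only a limit of this assay, > 10000 nM. One step between compounds differing in a single place is measured: an at least 1000-fold higher number from compound 2 to compound 3 (3.00 log units; beyond the scatter). The evidence behind it is the limit of > 10000 nM in this assay, at which 1 of the 3 values shown sits, so its true size is not bounded from above.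

Compound 4 `CCOC(=O)N1CCN(CC(=O)C(O)(c2ccccc2)C2CCCCC2)CC1` is not yet measured. It differs from compound 1 as follows: ethoxycarbonyl in place of allyl on an amine nitrogen in a ring. For the measured compounds named here, the only measured step that touches the same ring nitrogen is the one from compound 2 to compound 3, which was large; the group entering compound 4 is not the one that entered compound 3, so the same size cannot be assumed, but a rise in the number well beyond the scatter is the expectation, with a real chance that only a limit is returned.

Compound 4 is therefore expected near 2000 nM, between 300 nM and 10000 nM. The expected step is a 78-fold higher number from compound 1 to compound 4 (1.89 log units; beyond the scatter).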

Compound 4, antagonist equilibrium constant: > 10000 nM
Compound 4 gave a limit, no number; the forecaster's own chance of this, stated with the estimate: 30%; middle value at least 5.0-fold (0.69 log units) from the limit.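

Ethoxycarbonyl in place of allyl on the amine nitrogen in a ring gives an at least 390-fold higher number from compound 1 to compound 4 (2.59 log units; beyond the scatter), so a large rise in this assay at this position is no longer tied to 4-nitrophenyl and now appears on a second core. Ethoxycarbonyl has no ring, which shows that a ring in the entering group is not needed for such a step; among the four compounds shown, the two with plain numbers carry allyl or 3-phenylprop-2-en-1-yl on this nitrogen, while the two that return limits carry 4-nitrophenyl or ethoxycarbonyl. The step is only a lower bound, and ethoxycarbonyl and 4-nitrophenyl cannot be ranked against each other: the limit of > 10000 nM in this assay, at which 2 of the 4 values shown sit.

Still open, as far as these compounds go, is which part of ethoxycarbonyl goes with the rise: a plain propyl on this nitrogen would test the loss of the allyl double bond, and an acetyl would test the carbonyl without the ethoxy part. Also open, from the compounds shown here alone, is whether a benzyl on this nitrogen would keep a plain number, as a ring-bearing group joined through a carbon chain.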